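This account rests on a few compounds, and the source may have more. Where it says the series, first, only, none or still open, it means among the compounds named here.

Measured so far in an ADME assay on HFF cells (Homo sapiens) for cytotoxicity, with a stated time of 8 days; a lower number here means that less compound is tolerated, a higher number that more compound is tolerated:

Compound 1 `Nc1nc(NC2CC2)c2ncn(/C=C3/CC3(CO)CO)c2n1` gives > 300000 nM, which is a limit of the assay and not a number.
Compound 2 `CCCOc1nc(N)nc2c1ncn2/C=C1/CC1(CO)CO` gives > 300000 nM, again a limit rather than a number.
Compound 3 `CCCCCCCCSc1nc(N)nc2c1ncn2/C=C1/CC1(CO)CO` gives > 300000 nM, also a limit.

Compound 1 therefore stands only at a limit in this assay, and the two further values shown are limits as well. The three measured steps tell nothing about size: a step that the two limits leave unreadable from compound 1 to compound 2, a step that the two limits leave unreadable from compound 1 to compound 3 and a step that the two limits leave unreadable from compound 2 to compound 3 are each unreadable because of the limit of > 300000 nM in this assay, at which 3 of the 3 values shown sit.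

The untested compound 4 `CSc1nc(N)nc2c1ncn2/C=C1/CC1(CO)CO` differs from compound 1 in one place: methylsulfanyl in place of cyclopropylamino on an aromatic carbon. Among the measured compounds shown here, no measured step bears readably on this change; what the three measured compounds show is only that propoxy and octylsulfanyl in place of cyclopropylamino both left the value at the limit. The expectation for compound 4 is therefore no step beyond the scatter, a number no higher from compound 1 to compound 4 (the limit leaves the size open), with the value most likely again reported as a limit. Compound 4 is estimated at 300000 nM, with a range from 100000 nM to 1000000 nM.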

Compound 4, half-maximal cytotoxic concentration: > 300000 nM
Compound 4 was reported as a limit (the forecaster's own chance of this, stated with the estimate: 85%); the middle value sits exactly at the limit.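

In this assay, compound 4 stands at a limit, as do compound 1, compound 2 and compound 3, so none of its steps to these compounds can be read: the limit of > 300000 nM in this assay, at which 4 of the 4 values shown sit. The compounds shown leave open whether any group at this aromatic carbon would lower the tolerated concentration.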